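Aryl swap on the sulfur: compound 3 to compound 4

A few compounds are considered here, and "the series" means these few. Any claim that something is new, unique, unknown or untested is made for them only; others in the source may bear on it.

Three compounds share one core and differ only in the group on the sulfur: compound 1 (`Nc1ccccc1NC(=O)/C=C/c1ccc(CSc2ccc(Cl)cc2)cc1`), compound 2 (`Nc1ccccc1NC(=O)/C=C/c1ccc(CSc2cccc(F)c2)cc1`) and compound 3 (`Nc1ccccc1NC(=O)/C=C/c1ccc(CSc2cccc3ccccc23)cc1`). In a functional assay on HCT-116 cells (Homo sapiens) for inhibition, read by CCK-8 assay, with a stated time of 72 h, tested at 2 uM (a lower number here means less inhibition of growth, a higher number more inhibition of growth at the concentration tested), compound 1 gives 5.62%, compound 2 gives 7.95% and compound 3 gives 11%. Compound 3 thus stands level with the other two, as the steps show: a number 3.1 percentage points higher from compound 2 to compound 3 (within the scatter), and a number 5.4 percentage points higher from compound 1 to compound 3 (within the scatter). The remaining pair tells the same story: a number 2.3 percentage points higher from compound 1 to compound 2 (within the scatter).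

Compound 4 (`CC(C)(C)c1ccc(SCc2ccc(/C=C/C(=O)Nc3ccccc3N)cc2)cc1`) carries 4-(tert-butyl)phenyl in place of naphthalen-1-yl on a sulfur. The other neighbour of that sulfur, a saturated chain carbon, stays as it is. For the measured compounds named here, the nearest precedent is the exchange of naphthalen-1-yl with 4-chlorophenyl, read backwards from a number 5.4 percentage points higher from compound 1 to compound 3 (within the scatter), as this group also has a single ring. No change at this place has yet moved the number beyond the scatter, so no step beyond it is expected in this assay. The expected step is a number 3 percentage points lower from compound 3 to compound 4 (within the scatter). For compound 4 the estimated value is 8%, with an expected range of 1% to 18%.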

Compound 4, percent growth inhibition at one concentration: 6.66%
The estimate for compound 4 lay 1.3 percentage points above the measured number; the measured number falls inside the stated range.
By their numbers in this assay, from the lowest: compounds 1, 4, 2 and 3 (each within the scatter of the next).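

In this assay, 4-(tert-butyl)phenyl and naphthalen-1-yl have the same count of heavy atoms but one aromatic ring against two, and this exchange gives a number 4.3 percentage points lower from compound 3 to compound 4 (within the scatter), so the loss of the second aromatic ring at an unchanged carbon count does not move the number beyond the scatter. The branched alkyl substituent also leaves the reading level with the halogen-bearing single rings, with a number 1.3 percentage points lower from compound 2 to compound 4 (within the scatter) and a number 1 percentage points higher from compound 1 to compound 4 (within the scatter); the last of these is tert-butyl in place of chloro on an aromatic carbon, so this substituent exchange on the ring also stays within the scatter. No measurement at hand accounts for this uniform reading across the four groups on the sulfur.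

Every group on the sulfur shown so far is an aromatic carbon ring, so it remains open whether a cyclohexyl group, a longer alkyl chain, or a ring carrying an amine or a carboxylic acid would produce a step beyond the scatter. Because the read-out is growth inhibition at a single concentration, the compounds shown also leave open how these groups would compare across a full concentration series.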